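Adding a second chloro to compound 3: what to expect

The source may report more compounds than this note shows. Statements on the series, on what has been measured and on what is new or still open speak of the compounds shown alone.

Measured compounds:
- compound 1 `O=C(Nc1ncc([N+](=O)[O-])s1)c1ccc(Cl)cc1O`: "not determined" (no result reported)
- compound 2 `CC(=O)Oc1cc(Cl)ccc1C(=O)Nc1ncc([N+](=O)[O-])s1`: 100%
- compound 3 `CC(=O)Oc1ccc(Cl)cc1C(=O)Nc1ncc([N+](=O)[O-])s1`: 59.5%

All three compounds share one core, an amide bound to a nitrothiazole, and differ only in the substitution of the six-membered ring carrying the amide. In an ADME assay on HEK-293T cells (Homo sapiens) for cytotoxicity, read by MTT assay, tested at 25 uM (on this read-out higher numbers stand for a weaker effect at the one concentration tested and lower numbers for a stronger effect), compound 1 has no result. In this assay compound 2 gives 100%, which on this read-out means no cytotoxic effect at the single concentration tested. In this assay compound 3 gives 59.5%, the lower of the two numbers available, and the gap to compound 2 lies beyond the usual scatter, so compound 3 has the stronger effect of the two.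

Compound 4 `CC(=O)Oc1c(Cl)cc(Cl)cc1C(=O)Nc1ncc([N+](=O)[O-])s1` has not yet been measured. It differs from compound 3 in one place: chloro in place of hydrogen on an aromatic carbon, the new chloro sitting ortho to the acetoxy group and meta to the chloro group already present. Going by the values given here, no measured pair shows what such an addition does on this core. With nothing to anchor the size of the step, the expectation for this assay is a step of a number 4.5 percentage points lower from compound 3 to compound 4 (within the scatter), that is, little change beyond the scatter, with a slight lean toward a stronger effect. Compound 4 is therefore estimated at 55%, in a range from 30% to 90%.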

Compound 4, a percentage reported as activity, at one concentration (the size of the read-out at that concentration, not a potency): 100%
Estimate against measurement, compound 4: 45 percentage points below; the measured number lies above the stated range.
By their numbers in this assay, from the lowest: compound 3; then compounds 2 and 4 (each within the scatter of the next).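

In this assay, putting chloro in place of hydrogen at this one aromatic carbon, ortho to an acetoxy group and meta to a chloro group, gives a large step (a number 40.5 percentage points higher from compound 3 to compound 4 (beyond the scatter)). On this read-out the higher number means a weaker effect, so this position is not a silent one on the shared core: a change of a single heavy atom here is enough to weaken the effect of compound 3 well beyond the scatter. No measurement shown here explains why the step is this large.

Going by these compounds, whether the step belongs to chloro itself or would also appear with fluoro, a methyl group or an amine at the same carbon stays open. So does whether it would hold if the acetoxy group were a longer ester chain.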